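Methoxy in Place of Fluoro on the Fused Ring

A few compounds are considered here, and "the series" means these few. Any claim that something is new, unique, unknown or untested is made for them only; others in the source may bear on it.

Compound 1, `Cc1ccc(-c2ccc(C)n2-c2ccc(-c3nc4ccccc4s3)cc2)cc1`, in an ADME assay on MCF-10A cells (Homo sapiens) for cytotoxicity, read by MTT assay, with a stated time of 72 h (a higher number here means a weaker inhibitor, a lower number a stronger inhibitor), gives 30600 nM.
Compound 2, `Cc1ccc(-c2ccc(C)n2-c2ccc(-c3nc4ccc(F)cc4s3)cc2)cc1`, in this assay gives 33600 nM.
Compound 3, `Cc1ccc(-c2ccc([N+](=O)[O-])cc2)n1-c1ccc(-c2nc3ccc(F)cc3s2)cc1`, in this assay gives 39000 nM.

Compound 2 sits between the other two numbers, but neither gap separates it from them: the step of a 1.1-fold higher number from compound 1 to compound 2 (0.04 log units; within the scatter) and the step of a 1.2-fold higher number from compound 2 to compound 3 (0.06 log units; within the scatter) both fall within the scatter of this kind of measurement. All three compounds share the same core and return numbers that cannot be told apart.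

Compound 4, `COc1ccc2nc(-c3ccc(-n4c(C)ccc4-c4ccc(C)cc4)cc3)sc2c1`, differs from compound 2 in one place: methoxy in place of fluoro on an aromatic carbon. For the measured compounds named here, the one measured step that touches the same carbon is a 1.1-fold higher number from compound 1 to compound 2 (0.04 log units; within the scatter), in which fluoro replaced hydrogen there without moving the number beyond the scatter. The step of a 1.2-fold higher number from compound 2 to compound 3 (0.06 log units; within the scatter) changed a different ring and likewise stayed within the scatter. Going by the values given here, nothing measured so far shows this position, or any other, to be sensitive in this assay, so a second substituent swap on the same carbon is expected to leave the number essentially where it is.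

Compound 4 is therefore estimated at 33000 nM, with a range from 18000 nM to 60000 nM. The expected step is a 1.0-fold lower number from compound 2 to compound 4 (0.01 log units; within the scatter), which is within the scatter.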

Compound 4, half-maximal inhibitory concentration: 34000 nM
Compound 4: middle estimate off by 1.0-fold (0.01 log units), on the low side, and the stated range covers the measured number.
By their numbers in this assay, from the lowest: compounds 1, 2, 4 and 3 (each within the scatter of the next).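

Until now this carbon had only shown fluoro against hydrogen; methoxy brings two heavy atoms and one hydrogen-bond acceptor where fluoro has one heavy atom and none, and in this assay the step is still a 1.0-fold higher number from compound 2 to compound 4 (0.01 log units; within the scatter), while the comparison with hydrogen on the same carbon gives a 1.1-fold higher number from compound 1 to compound 4 (0.05 log units; within the scatter). Hydrogen, fluoro and methoxy on this aromatic carbon therefore cannot be told apart in this assay, so the tolerance seen for one small substituent now extends to a second, larger one that also carries a hydrogen-bond acceptor. No evidence is available that would account for these three numbers staying together.

What remains open is whether an amine, a carboxylic acid or a longer chain on this carbon would also stay within the scatter, since the compounds shown hold only hydrogen, fluoro and methoxy there. From the compounds shown here alone, it is also open whether methoxy would give the same reading when paired with the nitro group of compound 3 on the other ring.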